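The source may report more compounds than this note shows. Statements on the series, on what has been measured and on what is new or still open speak of the compounds shown alone.

In an ADME assay on Vero cells (Chlorocebus sabaeus) for cytotoxicity, read by MTT assay, with a stated time of 72 h (a higher number here means a weaker inhibitor, a lower number a stronger inhibitor), every value so far is a limit of the assay:
Compound 1 `COc1ccccc1C1CC(c2cc3ccccc3o2)=NN1C(=O)c1ccncc1` gives > 202000 nM.
Compound 2 `O=C(c1ccncc1)N1N=C(c2cc3ccccc3o2)CC1c1ccc(Cl)cc1` gives > 220000 nM.
Compound 3 `CCn1cc(C(=O)N2N=C(c3cc4ccccc4o3)CC2c2ccccc2C(=O)O)c(=O)c2ccc(C)nc21` gives > 196000 nM.

Compound 3 thus stands at a limit (the limit of > 196000 nM in this assay, at which 1 of the 3 values shown sits), and the other two values are limits as well the limit of > 202000 nM in this assay, at which 1 of the 3 values shown sits (the limit of > 220000 nM in this assay, at which 1 of the 3 values shown sits); no order among the three can be read. Within the data shown here, the one step measured between compounds that differ in a single place, a step that the two limits leave unreadable from compound 1 to compound 2, is unreadable for the same reason. Compound 4 `CCn1cc(C(=O)N2N=C(c3cc4ccccc4o3)CC2c2ccccc2)c(=O)c2ccc(C)nc21` differs from compound 3 by hydrogen in place of carboxy on an aromatic carbon. Among the measured compounds shown here, no measured step touches this change, and the measured steps give no size at all. Compound 4 is expected to sit at the same limit, with a step that the limit leaves unreadable from compound 3 to compound 4 of no readable size. The estimate for compound 4 is 200000 nM, ranging from 100000 nM to 400000 nM.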

Compound 4, half-maximal inhibitory concentration: > 210000 nM
Compound 4: a limit, no number (the forecaster's own chance of this, stated with the estimate: 85%); middle value at least 1.0-fold (0.02 log units) from the limit.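

The step between compound 3 and compound 4, hydrogen in place of carboxy on an aromatic carbon, cannot be read, as both values are limits of the assay. The compounds shown leave open whether any member of the series would give a number rather than a limit.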